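Swapping a Carboxylic Acid for Two Methyl Groups

The source may hold more compounds than are shown below. What is called first, only, known or untested is meant among the compounds shown, and "the series" means these compounds.

Three measured compounds share one core and differ only in the group on the amine nitrogen. Compound 1 `CC1(C)Oc2ccc(C#N)cc2[C@@H](/N=C(\NC#N)NCc2ccccc2)[C@@H]1O` carries a benzyl group there; in a functional assay (aorta) with Rattus norvegicus as the target (on this read-out higher numbers stand for weaker inhibition and lower numbers for stronger inhibition), compound 1 gives 2400 nM. Compound 2 `CC(=O)c1cccc(N/C(=N/[C@@H]2c3cc(C#N)ccc3OC(C)(C)[C@H]2O)NC#N)c1` bears a 3-acetylphenyl instead, and in this assay compound 2 gives 8400 nM, which is a 3.5-fold higher number from compound 1 to compound 2 (0.54 log units; beyond the scatter). Compound 3 `CC1(C)Oc2ccc(C#N)cc2[C@@H](/N=C(\NC#N)Nc2cccc(C(=O)O)c2)[C@@H]1O` has a 3-carboxyphenyl. In this assay compound 3 reaches only the limit of the measurement, > 100000 nM. It therefore stands at the far weak end of the numbers shown, with an at least 41-fold higher number from compound 1 to compound 3 (1.61 log units; beyond the scatter) and an at least 11-fold higher number from compound 2 to compound 3 (1.07 log units; beyond the scatter). Compound 4 `Cc1ccc(N/C(=N/[C@@H]2c3cc(C#N)ccc3OC(C)(C)[C@H]2O)NC#N)cc1C` is not yet measured; it differs from compound 3 by 3,4-dimethylphenyl in place of 3-carboxyphenyl on an amine nitrogen. The two steps into compound 3 bear on this change: both are large and both run toward weaker inhibition as the carboxyphenyl arrives, so taking it away again is expected to run the other way. I expect a large step toward stronger inhibition, an at least 20-fold lower number from compound 3 to compound 4 (1.30 log units; beyond the scatter), in this assay. My estimate for compound 4 is 5000 nM, within 1500 nM to 30000 nM.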

Compound 4, half-maximal inhibitory concentration: 5100 nM
Beside the measured number, compound 4's estimate is 1.0-fold (0.01 log units) below it; measured number inside the range.
By their numbers in this assay, from the lowest: compound 1; then compounds 4 and 2 (each within the scatter of the next). At a limit, above all of these: compound 3.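

The 3,4-dimethylphenyl brings back a measurable number in this assay (an at least 19-fold lower number from compound 3 to compound 4 (1.29 log units; beyond the scatter)), so the large loss belongs to the 3-carboxyphenyl and not to any phenyl ring on this amine nitrogen. That step gives only a minimum size, because one side of it is a limit and not a number: the limit of > 100000 nM in this assay, at which 1 of the 4 values shown sits. The other two steps are far smaller (a 1.6-fold lower number from compound 2 to compound 4 (0.22 log units; within the scatter); a 2.1-fold higher number from compound 1 to compound 4 (0.33 log units; beyond the scatter)), so the 3,4-dimethylphenyl sits with the 3-acetylphenyl and only a modest step from the benzyl.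

As far as these compounds go, what remains open is whether the loss is special to the carboxylic acid, or whether a phenyl ring carrying an amine or a hydroxy group would behave the same way. The compounds shown also cannot say why the carboxylic acid costs so much.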